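Swapping a nitrophenyl for a hydroxyethyl on a disulfide

A few compounds are considered here, and "the series" means these few. Any claim that something is new, unique, unknown or untested is made for them only; others in the source may bear on it.

Compound 1 `Cc1cn([C@H]2C[C@H](SSc3ccccc3[N+](=O)[O-])[C@@H](CO)O2)c(=O)[nH]c1=O` gives a limit of < 0.167 h in a physicochemical assay for metabolic stability, in the presence of a further agent that is not named here; on this read-out higher numbers stand for a longer-lived compound and lower numbers for a shorter-lived compound.
Compound 2 `Cc1cn([C@H]2C[C@H](SSc3ccc([N+](=O)[O-])cc3)[C@@H](CO)O2)c(=O)[nH]c1=O` gives a limit of < 0.167 h in this assay.

Compound 1 therefore stands at a limit, not at a number. Among the compounds with values here, the only measured step, a step that the two limits leave unreadable from compound 1 to compound 2, is unreadable because both values sit at the limit of < 0.167 h in this assay, at which 2 of the 2 values shown sit. Compound 3 `Cc1cn([C@H]2C[C@H](SSCCO)[C@@H](CO)O2)c(=O)[nH]c1=O` differs from compound 1 by 2-hydroxyethyl in place of 2-nitrophenyl on a sulfur. Within the data shown here, no measured step speaks to this change. Accordingly, the expected step here is a step that the limit leaves unreadable from compound 1 to compound 3. Compound 3 is expected to give 0.1 h in this assay, between 0.03 h and 0.5 h, most likely again as a limit.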

Compound 3, half-life: < 8 h
Compound 3 ended at the assay's limit (the forecaster's own chance of this, stated with the estimate: 70%); the middle value lies beyond the limit too.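

Compound 3 gives < 8 h in this assay, which is a limit and not a number. The steps to it from compound 1 and compound 2 therefore cannot be read. The compounds shown leave open whether 2-hydroxyethyl in place of either nitrophenyl group changes the half-life at all.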